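Swapping the Sulfamoyl for Phenyl on the Ring Nitrogen

The source may report more compounds than this note shows. Statements on the series, on what has been measured and on what is new or still open speak of the compounds shown alone.

Compound 1 `NS(=O)(=O)N1CCC(C(=O)/C(=N/O)Nc2ccc(F)c(Br)c2)CC1` is the point of departure. Within the data shown here, in an assay on tissue (HeLa cells) for inhibition of Indoleamine 2,3-dioxygenase 1 (Homo sapiens), with a stated time of 48 h (a lower number here means a stronger inhibitor, a higher number a weaker inhibitor), compound 1 gives 45 nM, the lowest of the three numbers measured so far. Compound 3 `O=C(/C(=N/O)Nc1ccc(F)c(Br)c1)C1CCN(S(=O)(=O)NCc2ccccc2)CC1` gives 262 nM in this assay. Compound 2 `O/N=C(/CC1CCCCC1)Nc1ccc(F)c(Br)c1` differs from compound 1 in several places. In this assay compound 2 gives 578 nM and stands furthest from compound 1.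

Among the measured compounds shown here, only one measured step is a single change, and it touches the same sulfamoyl group that is now in question: a 5.8-fold higher number from compound 1 to compound 3 (0.77 log units; beyond the scatter), obtained by placing benzyl in place of hydrogen on the sulfonamide nitrogen.

The unmeasured compound 4 `O=C(/C(=N/O)Nc1ccc(F)c(Br)c1)C1CCN(c2ccccc2)CC1` differs from compound 1 as follows: phenyl in place of sulfamoyl on an amine nitrogen in a ring. Where the step to compound 3 merely enlarged the sulfamoyl group, this change removes it entirely, with its hydrogen-bond donor and acceptors, and puts a bare aromatic ring in its place. A weakening step at least as large as the one already seen is therefore expected, so that the estimated step is an 8.9-fold higher number from compound 1 to compound 4 (0.95 log units; beyond the scatter). Compound 4 is accordingly expected to give about 400 nM in this assay, with a plausible range from 100 nM to 1600 nM.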

Compound 4, half-maximal inhibitory concentration: 1020 nM
The estimate for compound 4 lay 2.6-fold (0.41 log units) below the measured number, and the stated range covers the measured number.
By their numbers in this assay, from the lowest: compound 1; then compound 3; then compounds 2 and 4 (each within the scatter of the next).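

In this assay, the group on the ring nitrogen matters a great deal even when the rest of compound 1 is left untouched: putting phenyl in place of sulfamoyl gives a 23-fold higher number from compound 1 to compound 4 (1.36 log units; beyond the scatter) and counts as a large step. The earlier benzyl change, which kept the sulfamoyl group in place and only added to it, counted as a modest one. Of the three groups shown on this ring nitrogen, the plain sulfamoyl of compound 1 therefore gives the lowest number, and both of the other two lie beyond the scatter from it.

This single swap removes sulfamoyl and brings in phenyl in one move, so the compounds shown cannot tell whether the loss of the old group or the arrival of the new one counts for more. A methyl or acetyl group on the ring nitrogen, or a methanesulfonyl group that keeps the sulfur and its two oxygens but drops the sulfamoyl nitrogen, would help pull these two apart.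

No measurement at hand offers a reason for the size of this step.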